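This account rests on a few compounds, and the source may have more. Where it says the series, first, only, none or still open, it means among the compounds named here.

Working notes on the series.

Compound 3 `Cc1ccc(C2CNN=C2S(=O)(=O)CC2=NCCO2)cc1` gives 46.8% in a functional assay, tested at 100 ug/mL; a lower number here means a weaker effect, a higher number a stronger effect of the compound at the concentration tested. Compound 1 `Cc1ccc(C2CNN=C2S(=O)(=O)CC2=NCCS2)cc1` gives 45.1% in this assay; the step of a number 1.7 percentage points lower from compound 3 to compound 1 (within the scatter) comes with the change (a group of 5 heavy atoms (3 carbon, 1 nitrogen, 1 sulfur; one five-membered non-aromatic ring with 2 hetero atoms) in place of a group of 5 heavy atoms (3 carbon, 1 nitrogen, 1 oxygen; one five-membered non-aromatic ring with 2 hetero atoms), on a saturated chain carbon bound to a sulfonyl sulfur).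

Compound 2 `COc1ccc(C2=NOC(c3ccc(C)cc3)C2S(=O)(=O)CC2=NCCO2)cc1` gives 70.9% in this assay, the highest of the three numbers, beyond the scatter from both compound 3 and compound 1. The difference between the core of compound 2 and the core of compound 3 is not broken down here.

Compound 4 `COc1ccc(C2=NOC(c3ccc(C)cc3)C2S(=O)(=O)CC2=NCCS2)cc1` is not yet measured. It differs from compound 2 by a group of 5 heavy atoms (3 carbon, 1 nitrogen, 1 sulfur; one five-membered non-aromatic ring with 2 hetero atoms) in place of a group of 5 heavy atoms (3 carbon, 1 nitrogen, 1 oxygen; one five-membered non-aromatic ring with 2 hetero atoms), on a saturated chain carbon bound to a sulfonyl sulfur, the same change that separates compound 3 from compound 1. For compound 4 the step of a number 1.9 percentage points lower from compound 2 to compound 4 (within the scatter) is expected to be small, beside the earlier a number 1.7 percentage points lower from compound 3 to compound 1 (within the scatter), resting on that single pair alone. Compound 4 is therefore estimated at 69% in this assay, expected between 55% and 81%.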

Compound 4, a percentage reported as activity, at one concentration (the size of the read-out at that concentration, not a potency): 52.6%
Beside the measured number, compound 4's estimate is 16.4 percentage points above it; the measured number lies below the stated range.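

The swap of the oxygen-containing group for the sulfur-containing group, on a saturated chain carbon bound to a sulfonyl sulfur, gives a number 18.3 percentage points lower from compound 2 to compound 4 (beyond the scatter) in this assay. The size of this step therefore does not carry over from one core to the other: the same change on two cores in this assay, a number 1.7 percentage points lower (within the scatter) from compound 3 to compound 1 and a number 18.3 percentage points lower (beyond the scatter) from compound 2 to compound 4, 16.6 percentage points apart, beyond the scatter of two such steps. With a single pair on each core, this shows only that the result of the change depends on the core in these four compounds, not which feature of the core of compound 2 sets the two steps apart.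

Still open, as far as these compounds go, is how an amine or a longer chain would behave on that saturated chain carbon, on either core. Also open, from the compounds shown here alone, is whether a third core would follow the smaller step or the larger one.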